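Benzyl Replaces 2-(Pyridin-2-yl)ethoxy: Cytotoxicity Expected Unchanged

This account rests on a few compounds, and the source may have more. Where it says the series, first, only, none or still open, it means among the compounds named here.

Of the compounds shown here, three sharing one core have been tested in an ADME assay on PC-3 cells (Homo sapiens) for cytotoxicity, read by WST assay, tested at 100 uM; on this read-out lower numbers stand for less inhibition and higher numbers for more inhibition at the one concentration tested (going by the name of the read-out). Compound 1 `Cc1nc(-c2cccc(C(=O)N3CCCC(C(=O)Nc4ccc(Cl)cc4)C3)c2)no1` gives 0%, and compound 3 `C=Cc1cccc(C(=O)N2CCCC(C(=O)Nc3ccc(Cl)cc3)C2)c1` gives 0%; the step of no change at the digits printed from compound 1 to compound 3 (within the scatter) shows that this exchange on the aromatic ring left the read-out untouched. Compound 2 `O=C(Nc1cccc(OCCc2ccccn2)c1)C1CCCN(C(=O)c2cc(C(F)(F)F)cc(C(F)(F)F)c2)C1` gives 5%; this number sits apart from compound 1 and from compound 3 only by amounts inside the usual scatter, so none of the three shows cytotoxicity worth noting at the tested concentration. Compound 4 `O=C(Nc1cccc(Cc2ccccc2)c1)C1CCCN(C(=O)c2cc(C(F)(F)F)cc(C(F)(F)F)c2)C1` differs from compound 2 in one place: benzyl in place of 2-(pyridin-2-yl)ethoxy on an aromatic carbon. For the measured compounds named here, no measured step covers this exact change; the single step available, from compound 1 to compound 3, altered a different aromatic substituent and produced nothing beyond the scatter. Since every measured compound sits near the bottom of the scale, the expectation is that compound 4 stays there as well, with a number 2 percentage points lower from compound 2 to compound 4 (within the scatter) meaning no shift beyond the scatter. Compound 4 is therefore estimated at 3%, within 0% to 15%.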

Compound 4, a percentage reported as inhibition, at one concentration (the size of the read-out at that concentration, not a potency): 0%
Beside the measured number, compound 4's estimate is 3 percentage points above it; the measured number falls inside the stated range.
By their numbers in this assay, from the lowest: compounds 1, 3, 4 and 2 (each within the scatter of the next).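

At this aromatic carbon, meta to a large group, putting benzyl in place of 2-(pyridin-2-yl)ethoxy gives a number 5 percentage points lower from compound 2 to compound 4 (within the scatter) in this assay. The exchange takes away the nitrogen and oxygen atoms and both hydrogen-bond acceptors of the leaving group, shortens the link to the outer aromatic ring, and still leaves the read-out inside the scatter, which the earlier step, made on a different aromatic substituent, could not show for this position. Nothing available explains this outcome.

Still open, on these data alone, is whether an amine or a carboxylic acid at this position, or a longer chain ending in a phenyl ring, would keep the number near the bottom of the scale. As far as these compounds go, every reading also comes from a single concentration, so how these compounds behave at other concentrations remains unknown.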